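This account rests on a few compounds, and the source may have more. Where it says the series, first, only, none or still open, it means among the compounds named here.

Measured compounds:
Compound 1 `CCCCCCCCCCCCCCOCC(COc1ccc(Cc2noc(=O)[nH]2)cc1)Oc1ccc(Cc2noc(=O)[nH]2)cc1` gives 7.64 in a physicochemical assay for lipophilicity; on this read-out higher numbers stand for higher lipophilicity and lower numbers for lower lipophilicity.
Compound 2 `CCCCCCCCCCCCCCOC(CO)COc1ccc(-c2noc(=O)[nH]2)cc1` gives 6.59 in this assay.
Compound 3 `CCCCCCCCCCCCCCOC(COc1ccc(Cc2noc(=O)[nH]2)cc1)COc1ccc(Cc2noc(=O)[nH]2)cc1` gives 7.64 in this assay.

Of these three, compound 2 stands lowest in this assay; compound 1 lies above it by a gap beyond the scatter, and compound 3 lies above it by the same gap, also beyond the scatter. Compound 1 and compound 3 show the same number. Compound 2 carries a free hydroxymethyl group and a single ring bearing the acidic heterocycle, whereas compound 1 and compound 3 each carry two such ring arms.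

Compound 4 `CCCCCCCCCCCCCCOC(COCC)COc1ccc(-c2noc(=O)[nH]2)cc1` has not yet been measured. It differs from compound 2 in one place: ethyl in place of hydrogen on an oxygen on a saturated carbon. Among the compounds with values here, no pair of measured compounds shares this change, so the size of the step must be judged from the change itself. A hydroxy to ethoxy exchange is expected to raise the value in this assay by about a unit, clearly beyond the scatter. Compound 4 is therefore estimated at 7.7, within 7.1 to 8.3, an expected step of a number 1.11 log units higher from compound 2 to compound 4 (beyond the scatter).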

Compound 4, partition coefficient: 7.34
Compound 4: the middle estimate sits 0.36 log units above what was measured; the range from low to high includes it.
By their numbers in this assay, from the lowest: compound 2; then compounds 4, 1 and 3 (each within the scatter of the next).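

Within the data shown here, putting ethyl in place of hydrogen on this oxygen gives the first reading of a single change: in this assay the step is a number 0.75 log units higher from compound 2 to compound 4 (beyond the scatter), a modest move that still lies beyond the scatter. The earlier compounds shown here included no pair differing in one place, so they could not show that the number responds to what is attached at this oxygen on a saturated carbon. Nothing measured here accounts for the size of this step.

From the compounds shown here alone, it remains open whether the number would keep rising with a longer chain on this oxygen, or how it would respond to a methyl group or a carboxylic acid there. A single pair also cannot show whether the same change would give a similar step on another core.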